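A few compounds are considered here, and "the series" means these few. Any claim that something is new, unique, unknown or untested is made for them only; others in the source may bear on it.

Measured so far:
compound 1 `CS(=O)(=O)Nc1ccc(O)c2c1CCCC2c1c[nH]cn1`: 4.61
compound 2 `COc1ccc(NS(C)(=O)=O)c2c1C(c1c[nH]cn1)CCC2`: 4.81

In a functional assay on Urethra for agonist activity at Alpha-1A adrenergic receptor (Oryctolagus cuniculus) (a lower number here means a less potent compound, a higher number a more potent compound, by a factor of ten per unit of this negative logarithm), compound 2 gives 4.81, and the step of a number 0.20 log units higher from compound 1 to compound 2 (within the scatter) is within the scatter, so compound 2 and compound 1 cannot be told apart on these two numbers. Compound 3 `Cc1ccc(NS(C)(=O)=O)c2c1C(c1c[nH]cn1)CCC2` differs from compound 2 by methyl in place of methoxy on an aromatic carbon. For the measured compounds named here, no measured step touches this exchange; the only step on record, a number 0.20 log units higher from compound 1 to compound 2 (within the scatter), altered the same oxygen and was small. Compound 3 is therefore expected to shift by a number 0.11 log units lower from compound 2 to compound 3 (within the scatter), nothing beyond the scatter. Compound 3 is estimated at 4.7, between 4.2 and 5.2.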

Compound 3, negative logarithm of the half-maximal effective concentration: 4.4
Compound 3: the middle estimate sits 0.30 log units above what was measured; measured number inside the range.
By their numbers in this assay, from the lowest: compounds 3, 1 and 2 (each within the scatter of the next, the first and the last beyond it).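

In this assay, for the compounds shown here, methyl in place of methoxy on this aromatic carbon, para to a methanesulfonamido group, gives the first step beyond the scatter (a number 0.41 log units lower from compound 2 to compound 3 (beyond the scatter)). Methyl in place of hydroxy at the same carbon stays within the scatter (a number 0.21 log units lower from compound 1 to compound 3 (within the scatter)), so compound 1 and compound 3 cannot be told apart, and only the methoxy and methyl pair separates here, modestly. Nothing available explains this result. Still open, as far as these compounds go, is how an amine, a chlorine or a longer chain such as ethoxy on this carbon would compare with methoxy.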